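The source may report more compounds than this note shows. Statements on the series, on what has been measured and on what is new or still open speak of the compounds shown alone.

Of the compounds shown here, three sharing one core have been measured in an assay on microsomes from liver for inhibition of 3-hydroxy-3-methylglutaryl-coenzyme A reductase (Rattus norvegicus); a lower number here means a stronger inhibitor, a higher number a weaker inhibitor. Compound 1 `CC(C)c1c(C(=O)NCc2ccc(Cl)cc2)nn(-c2ccc(F)cc2)c1OC[C@@H](O)C[C@@H](O)CC(=O)O` gives 6.7 nM, compound 2 `CC(C)c1c(C(=O)N(C)Cc2cccc(Cl)c2)nn(-c2ccc(F)cc2)c1OC[C@@H](O)C[C@@H](O)CC(=O)O` gives 8.3 nM, and compound 3 `CC(C)c1c(C(=O)N(C)Cc2ccc(F)c(F)c2)nn(-c2ccc(F)cc2)c1OC[C@@H](O)C[C@@H](O)CC(=O)O` gives 5.7 nM. Within the data shown here, compound 3 shows the lowest of the three numbers, but its gaps to the others are small: the step from compound 1 to compound 3 is a 1.2-fold lower number from compound 1 to compound 3 (0.07 log units; within the scatter), and the step from compound 2 to compound 3 is a 1.5-fold lower number from compound 2 to compound 3 (0.16 log units; within the scatter), so no compound can be called the strongest here.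

Compound 4 `CC(C)c1c(C(=O)N(C)Cc2ccc(F)cc2)nn(-c2ccc(F)cc2)c1OC[C@@H](O)C[C@@H](O)CC(=O)O` is not yet measured. It differs from compound 3 in one place: hydrogen in place of fluoro on an aromatic carbon. Among the measured compounds shown here, the steps that bear on this are the changes of the benzyl ring pattern already seen, from compound 1 to compound 2 at a 1.2-fold higher number from compound 1 to compound 2 (0.09 log units; within the scatter) and from compound 2 to compound 3 at a 1.5-fold lower number from compound 2 to compound 3 (0.16 log units; within the scatter), both within the scatter. Removing one fluoro group is therefore expected to leave this assay result essentially unchanged, with an expected step of a 1.2-fold higher number from compound 3 to compound 4 (0.09 log units; within the scatter). Compound 4 is estimated to give 7 nM, within a range of 3.5 nM to 14 nM.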

Compound 4, half-maximal inhibitory concentration: 18 nM
Estimate against measurement, compound 4: 2.6-fold (0.41 log units) below, and the stated range ends below it.
By their numbers in this assay, from the lowest: compounds 3, 1 and 2 (each within the scatter of the next); then compound 4.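

Among these compounds, until now every change on the benzyl ring stayed within the scatter, so the ring seemed to accept such changes freely; going from 3,4-difluorobenzyl to 4-fluorobenzyl is the first to stand out in this assay, with a 3.2-fold higher number from compound 3 to compound 4 (0.50 log units; beyond the scatter) as its size. The same compound also separates from the two chlorine-bearing compounds, with a 2.2-fold higher number from compound 2 to compound 4 (0.34 log units; beyond the scatter) on one side and a 2.7-fold higher number from compound 1 to compound 4 (0.43 log units; beyond the scatter) on the other, so the benzyl ring pattern matters more than the first three compounds suggested. Nothing available explains why this single fluoro group counts.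

As far as these compounds go, whether fluorine itself is needed on this aromatic carbon stays open, since only fluoro and hydrogen are compared there. A methyl, methoxy or nitrile group on that carbon, with the 4-fluoro group kept, would help to settle this.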